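A few compounds are considered here, and "the series" means these few. Any claim that something is new, unique, unknown or untested is made for them only; others in the source may bear on it.

Compound 1 `O=C(NCc1ccccc1)c1cn(-c2ccccc2)nc1-c1cccnc1` and compound 2 `O=C(NCc1ccccc1)c1cn(-c2ccccc2)nc1-c1ccncc1` share a core and differ by pyridin-4-yl in place of pyridin-3-yl on an aromatic carbon. In a functional assay on HeLa cells (Homo sapiens) for cytotoxicity, read by MTT assay, with a stated time of 48 h (a higher number here means a weaker inhibitor, a lower number a stronger inhibitor), compound 1 gives only a limit, > 100000 nM. In this assay compound 2 likewise gives only a limit, > 100000 nM. The step that the two limits leave unreadable from compound 1 to compound 2 therefore cannot be sized; both values sit at the limit of > 100000 nM in this assay, at which 2 of the 2 values shown sit. Compound 3 `CCc1ccc(OC(=O)c2cn(-c3ccccc3)nc2-c2ccncc2)cc1` carries 4-ethylphenoxy in place of benzylamino on a carbonyl carbon. Among the compounds with values here, no measured step bears on this change, and nothing here points away from the limit. Compound 3 is estimated at 150000 nM, range 40000 nM to 500000 nM, an expected step that the limit leaves unreadable from compound 2 to compound 3.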

Compound 3, half-maximal inhibitory concentration: > 100000 nM
Compound 3 ended at the assay's limit (the forecaster's own chance of this, stated with the estimate: 65%); the middle value lies beyond the limit too.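

In this assay, no step can be read from compound 2 to compound 3, as both values are limits: the limit of > 100000 nM in this assay, at which 3 of the 3 values shown sit.

Left open is whether 4-ethylphenoxy in place of benzylamino changes cytotoxicity at all, and how far compound 1, compound 2 and compound 3 lie past that limit.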